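This account rests on a few compounds, and the source may have more. Where it says the series, first, only, none or still open, it means among the compounds named here.

Within the data shown here, compound 1 `CCOC(=O)C(C)Oc1cc(O)c2c(=O)c(O)c(-c3ccc(OC)cc3)oc2c1CC=C(C)C` is the only member of this small set with a number attached. In an ADME assay on Vero cells (Chlorocebus sabaeus) for cytotoxicity, read by MTT assay (a higher number here means a weaker inhibitor, a lower number a stronger inhibitor), compound 1 gives 1400 nM. Compound 2 `COc1ccc(-c2oc3c(CC=C(C)C)c(OCCCC(=O)O)cc(O)c3c(=O)c2O)cc1` shares the core of compound 1 and carries a 3-carboxypropoxy chain in place of the ester-bearing chain, but in this assay compound 2 gives "not determined" (no result reported), so compound 2 stands nowhere on the numbers shown and can serve only as a structural reference point. Compound 3 `CCOC(=O)COc1cc(O)c2c(=O)c(O)c(-c3ccc(OC)cc3)oc2c1CC=C(C)C` has not yet been measured. It differs from compound 2 in that the two have the same atoms joined differently: ethoxycarbonyl in place of 2-carboxyethyl on a saturated chain carbon bound to an oxygen on an aromatic ring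

Among the measured compounds shown here, with no number for compound 2, no step from compound 2 to compound 3 in this assay can be sized or given a direction; the only anchor is compound 1, whose reading of 1400 nM comes from a compound that likewise carries an ethyl ester on the chain bound to the aromatic oxygen. On that basis compound 3 is expected to land near compound 1, with an estimated 1500 nM in this assay, the range running from 500 nM to 5000 nM.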

Compound 3, half-maximal inhibitory concentration: 1400 nM
The estimate for compound 3 lay 1.1-fold (0.03 log units) above the measured number; the measured number falls inside the stated range.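

In this assay, among these compounds, the pair gives the first readable step in this set, no change at the digits printed from compound 1 to compound 3 (within the scatter), with hydrogen in place of methyl on a saturated chain carbon bound to a carbonyl carbon and an oxygen on an aromatic ring. Until now there was a single number and nothing to set it against; this step shows that, with the ethoxycarbonyl group and the shared core held constant, this one methyl group on the chain can be removed without a reading that stands apart from the scatter. Nothing available explains this result, and it rests on this single pair of compounds.

Steps involving compound 2 cannot be read, so the compounds shown say nothing about how the free carboxylic acid of its 3-carboxypropoxy chain compares with the ethyl esters in this assay. Also open, from the compounds shown here alone, is whether the same flat result would hold for a larger group than methyl on that chain carbon, such as an ethyl or a phenyl group, or for an amide or an amine in place of the ester.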